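Removing the methoxy from a bis(trifluoromethyl)benzenesulfonamide

A few compounds are considered here, and "the series" means these few. Any claim that something is new, unique, unknown or untested is made for them only; others in the source may bear on it.

Measured compounds:
compound 1, `COc1cccc(CNCCCNS(=O)(=O)c2cc(C(F)(F)F)cc(C(F)(F)F)c2)c1`, 2400 nM
compound 2, `O=S(=O)(NCCCNCc1cccc(Cl)c1)c1cc(C(F)(F)F)cc(C(F)(F)F)c1`, 2700 nM
compound 3, `CN(CCCNS(=O)(=O)c1cc(C(F)(F)F)cc(C(F)(F)F)c1)Cc1ccccc1`, 30000 nM

In a functional assay on HPAC cells (Homo sapiens) for inhibition, read by MTT assay, with a stated time of 72 h (a lower number here means a stronger inhibitor of growth, a higher number a weaker inhibitor of growth), compound 1 gives the lowest of the three numbers, with compound 2 lying within the scatter of it and compound 3 far above both. The step of a 1.1-fold higher number from compound 1 to compound 2 (0.05 log units; within the scatter) shows that chloro in place of methoxy on an aromatic carbon changes little. The steps of a 13-fold higher number from compound 1 to compound 3 (1.10 log units; beyond the scatter) and an 11-fold higher number from compound 2 to compound 3 (1.05 log units; beyond the scatter) are large, but each combines the loss of the substituent on the aromatic carbon with a methyl on the chain nitrogen, so they cannot be separated into two parts on these data.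

Compound 4, `O=S(=O)(NCCCNCc1ccccc1)c1cc(C(F)(F)F)cc(C(F)(F)F)c1`, is made from compound 1 by the change (hydrogen in place of methoxy on an aromatic carbon). Going by the values given here, only one measured step, that from compound 1 to compound 2, touches the same carbon, and it lay within the scatter; the large steps to compound 3 carry an added change as well. Compound 4 is therefore expected to show a step of about a 1.5-fold higher number from compound 1 to compound 4 (0.16 log units; within the scatter), a small move toward the higher numbers, if any beyond the scatter. The estimate for compound 4 in this assay is 3500 nM, with a range from 1500 nM to 8000 nM.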

Compound 4, concentration for 50% growth inhibition: 3200 nM
Compound 4: the middle estimate sits 1.1-fold (0.04 log units) above what was measured; low and high end bracket the measured number.
By their numbers in this assay, from the lowest: compounds 1, 2 and 4 (each within the scatter of the next); then compound 3.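

In this assay, the methoxy on the aromatic carbon turns out not to be needed for the growth inhibition seen here: replacing it with hydrogen gives a 1.3-fold higher number from compound 1 to compound 4 (0.12 log units; within the scatter), and the comparison with the chloro analogue gives a 1.2-fold higher number from compound 2 to compound 4 (0.07 log units; within the scatter). Methoxy, chloro and hydrogen at this place, meta to a large group, therefore cannot be told apart by these numbers. Going by these compounds alone, compound 4 also separates the two changes that were combined in the earlier steps to compound 3: with the aromatic ring the same in both, hydrogen in place of methyl on the amine nitrogen gives a 9.4-fold lower number from compound 3 to compound 4 (0.97 log units; beyond the scatter), beyond the scatter, so the gap belongs to that methyl and not to the aromatic substituent.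

Nothing measured alongside these compounds offers a reason for either result. The compounds shown leave open whether a carboxylic acid or a nitrile on the same aromatic carbon would also stay within the scatter of compound 4, and whether an ethyl on the amine nitrogen would match the step seen with methyl.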